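Amide to Urea at the End of the Chain

The source may hold more compounds than are shown below. What is called first, only, known or untested is meant among the compounds shown, and "the series" means these compounds.

Compound 1 `COc1cccc(-c2nn(-c3ccccc3)cc2-c2ccnc(NCCCNC(=O)c3cccc(C(F)(F)F)c3)c2)c1` and compound 2 `COc1cccc(-c2nn(-c3ccccc3)cc2-c2ccnc(NCCNC(=O)Nc3cccc(C(F)(F)F)c3)c2)c1` share the same core and differ only in the chain and the group at its end. In a functional assay on MDA-MB-468 cells (Homo sapiens) for antiproliferative activity (a higher number here means a weaker inhibitor of growth, a lower number a stronger inhibitor of growth), compound 1 gives 1950 nM, and compound 2 gives 1700 nM. Compound 1 has the higher of these two numbers, but the gap to compound 2 falls within the usual scatter, so the two cannot be told apart on this evidence.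

Compound 3 `COc1cccc(-c2nn(-c3ccccc3)cc2-c2ccnc(NCCCNC(=O)Nc3ccc(Cl)c(Cl)c3)c2)c1` awaits measurement in this assay. Relative to compound 1 it changes in one place: (3,4-dichlorophenyl)amino in place of 3-(trifluoromethyl)phenyl on a carbonyl carbon. Going by the values given here, no measured pair shows this single change on its own, so its size is not known from the data. Compound 2 already carries a urea of the same kind and gives 1700 nM, a number indistinguishable from that of compound 1. A step of the same kind, none beyond the scatter, is therefore expected, as the estimated 1.2-fold lower number from compound 1 to compound 3 (0.09 log units; within the scatter) expresses. Compound 3 is estimated at 1600 nM, with a likely range from 600 nM to 4500 nM.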

Compound 3, concentration for 50% growth inhibition: 1920 nM
Compound 3: middle estimate off by 1.2-fold (0.08 log units), on the low side; measured number inside the range.
By their numbers in this assay, from the lowest: compounds 2, 3 and 1 (each within the scatter of the next).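

Replacing 3-(trifluoromethyl)phenyl with (3,4-dichlorophenyl)amino on the carbonyl carbon turns the amide of compound 1 into a urea, and in this assay this gives a 1.0-fold lower number from compound 1 to compound 3 (0.01 log units; within the scatter) and so no change that can be told from the scatter. Going by these compounds alone, this is the first reading of the change on its own, with the chain held constant; compound 2 could not give it, since it differs from compound 1 in the chain as well as in the group at its end. The swap brings in one hydrogen-bond donor and replaces the trifluoromethyl group with two chlorines, yet the number stays put, and no measurement shown here explains why.

The swap changes the link and the ring substituents together, so a urea carrying 3-(trifluoromethyl)phenyl or an amide carrying 3,4-dichlorophenyl would be needed to separate the two parts, as they might either have no effect or cancel each other out. Also open, as far as these compounds go, is whether anything at this end can move the number beyond the scatter, such as an amine or a carboxylic acid in place of the ring, or a longer chain.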